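The source may report more compounds than this note shows. Statements on the series, on what has been measured and on what is new or still open speak of the compounds shown alone.

Two compounds built on the same core differ only in the group attached to one carbonyl carbon. Compound 1 `O=C(N[C@H]1CCC[C@H](NC(=O)C2CCCCC2)C1)c1cccc(Cl)c1` carries a cyclohexyl group there, and in a functional assay on HEK293 cells for antagonist activity at metabotropic glutamate receptor 5 (Homo sapiens), read by FLIPR and calcium flux (on this read-out lower numbers stand for stronger inhibition and higher numbers for weaker inhibition), compound 1 gives 857 nM. Compound 2 `O=C(N[C@H]1CCC[C@H](NC(=O)c2cccc(Cl)c2)C1)c1cccnc1` carries pyridin-3-yl in that place, and in this assay compound 2 gives 612 nM. The step of a 1.4-fold lower number from compound 1 to compound 2 (0.15 log units; within the scatter) is small, so these two numbers cannot be told apart; compound 2 merely has the lower of the two numbers shown so far.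

Compound 3 `O=C(N[C@H]1CCC[C@H](NC(=O)c2cccc(Cl)c2)C1)c1ccncc1` has not yet been measured. It differs from compound 2 by pyridin-4-yl in place of pyridin-3-yl on a carbonyl carbon. Among the measured compounds shown here, no measured step moves the ring nitrogen in this way. For the measured compounds named here, the only step in hand, a 1.4-fold lower number from compound 1 to compound 2 (0.15 log units; within the scatter), swaps cyclohexyl for pyridin-3-yl and stays within the scatter, so it offers no direction for this smaller change. Nothing here points to a move beyond the scatter either way, and in this assay the expected step is a 1.1-fold higher number from compound 2 to compound 3 (0.06 log units; within the scatter). Compound 3 is accordingly estimated at 700 nM, with a range from 250 nM to 2000 nM.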

Compound 3, half-maximal inhibitory concentration: 300 nM
Compound 3: middle estimate off by 2.3-fold (0.37 log units), on the high side; the range from low to high includes it.
By their numbers in this assay, from the lowest: compound 3; then compounds 2 and 1 (each within the scatter of the next).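

This result shows that the position of the nitrogen in the ring on this carbonyl carbon can matter, even though the swap keeps the same atoms and the same counts: in this assay the change gives a 2.0-fold lower number from compound 2 to compound 3 (0.31 log units; beyond the scatter). The earlier pair could not show this, since replacing cyclohexyl with pyridin-3-yl stayed within the scatter and left open whether this position responds to any change at all, whereas pyridin-4-yl separates from cyclohexyl as well, with a 2.9-fold lower number from compound 1 to compound 3 (0.46 log units; beyond the scatter), and compound 3 now has the lowest number of the three. Nothing measured here explains why the pyridin-4-yl compound gives the lower number, and the steps are modest, so this remains an observation from three compounds rather than a general rule.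

As far as these compounds go, it remains open where pyridin-2-yl or a plain phenyl ring would fall at this carbonyl carbon, and so whether the ring nitrogen is needed at all. From the compounds shown here alone, it is also open whether adding a methyl group or an amine to the pyridin-4-yl ring would lower the number further or raise it.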